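Working notes: aryl change on an aromatic nitrogen

The source may hold more compounds than are shown below. What is called first, only, known or untested is meant among the compounds shown, and "the series" means these compounds.

The series shares one core; compound 1 `Cn1cc(NC(=O)c2cccc(NS(=O)(=O)c3ccccc3)c2)cn1` carries methyl on an aromatic nitrogen, compound 2 `O=C(Nc1cnn(-c2ccccc2)c1)c1cccc(NS(=O)(=O)c2ccccc2)c1` phenyl, compound 3 `Cc1ccc(-n2cc(NC(=O)c3cccc(NS(=O)(=O)c4ccccc4)c3)cn2)cc1` 4-methylphenyl. In a functional assay on HeLa cells (Homo sapiens) for inhibition, read by MTT assay, with a stated time of 48 h (a lower number here means a stronger inhibitor, a higher number a weaker inhibitor), compound 1 gives 78500 nM, compound 2 gives 15300 nM, and compound 3 gives 3120 nM. Compound 3 stands lowest of the three numbers; the steps of a 5.1-fold lower number from compound 1 to compound 2 (0.71 log units; beyond the scatter), a 25-fold lower number from compound 1 to compound 3 (1.40 log units; beyond the scatter) and a 4.9-fold lower number from compound 2 to compound 3 (0.69 log units; beyond the scatter) all point the same way, each beyond the scatter.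

Compound 4 `COc1cccc(-n2cc(NC(=O)c3cccc(NS(=O)(=O)c4ccccc4)c3)cn2)c1` is not yet measured. The change is 3-methoxyphenyl in place of 4-methylphenyl on an aromatic nitrogen. Among the measured compounds shown here, no measured step swaps one substituent on the phenyl for another or moves it. The nearest bearing is a 4.9-fold lower number from compound 2 to compound 3 (0.69 log units; beyond the scatter), which shows that a methyl on the phenyl mattered, and a 25-fold lower number from compound 1 to compound 3 (1.40 log units; beyond the scatter), which shows that the aryl group as a whole matters most. Whether 3-methoxyphenyl keeps the gain seen with 4-methylphenyl cannot be read from these numbers. For compound 4 the expected step is a 1.4-fold higher number from compound 3 to compound 4 (0.16 log units; within the scatter), which is not expected to go beyond the scatter. The estimate for compound 4 in this assay is 4500 nM, range 1500 nM to 13000 nM.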

Compound 4, half-maximal inhibitory concentration: 26200 nM
Estimate against measurement, compound 4: 5.8-fold (0.77 log units) below; measured number outside the range, above it.
By their numbers in this assay, from the lowest: compound 3; then compounds 2 and 4 (each within the scatter of the next); then compound 1.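

In this assay, the gain seen with 4-methylphenyl does not carry over to 3-methoxyphenyl (an 8.4-fold higher number from compound 3 to compound 4 (0.92 log units; beyond the scatter)), so a substituent on the phenyl does not by itself secure the gain, and the effect depends on which substituent is present and where it sits. The methoxy adds nothing measurable over the plain phenyl (a 1.7-fold higher number from compound 2 to compound 4 (0.23 log units; within the scatter)), yet 3-methoxyphenyl still keeps part of the advantage of an aryl group over methyl on the aromatic nitrogen (a 3.0-fold lower number from compound 1 to compound 4 (0.48 log units; beyond the scatter)). No supporting data on hand explain the loss relative to compound 3.

The compounds shown do not separate the swap of methyl for methoxy from the change of place on the phenyl. As far as these compounds go, how a phenyl bearing an amine or a carboxylic acid, or a longer chain on the aromatic nitrogen, would behave also remains open.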